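This account rests on a few compounds, and the source may have more. Where it says the series, first, only, none or still open, it means among the compounds named here.

Working notes on the series. Compound 1 `COc1cc(/C=C/C(=O)Nc2cc3c(Nc4ccc(F)c(Cl)c4)ncnc3cc2O[C@H]2CCOC2)cc(OC)c1OC` carries the shared core with a 3,4,5-trimethoxyphenyl on a double-bonded chain carbon bound to a double-bonded chain carbon. Among the measured compounds shown here, in a functional assay on A549 cells (Homo sapiens) for cytotoxicity, read by MTT assay, with a stated time of 72 h (a lower number here means a stronger inhibitor, a higher number a weaker inhibitor), compound 1 gives 4150 nM, the lowest of the two numbers measured so far. For the measured compounds named here, the only comparator is compound 2 `COc1ccc(/C=C/C(=O)Nc2cc3c(Nc4ccc(F)c(Cl)c4)ncnc3cc2O[C@H]2CCOC2)c(OC)c1`; in this assay compound 2 gives 9350 nM, and the measured step of a 2.3-fold higher number from compound 1 to compound 2 (0.35 log units; beyond the scatter) is the one step that bears on the present question, since it also alters the aryl ring on that chain carbon.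

Compound 3 `COc1ccc(/C=C/C(=O)Nc2cc3c(Nc4ccc(F)c(Cl)c4)ncnc3cc2O[C@H]2CCOC2)cc1` differs from compound 1 by 4-methoxyphenyl in place of 3,4,5-trimethoxyphenyl on a double-bonded chain carbon bound to a double-bonded chain carbon. The change touches the same ring as the step to compound 2, and trims it further than that step did. Going by the values given here, with only a single relevant step, the expectation is a higher number in this assay for compound 3, in the direction of a 2.3-fold higher number from compound 1 to compound 2 (0.35 log units; beyond the scatter) and of roughly that size or somewhat larger, expected as a 2.7-fold higher number from compound 1 to compound 3 (0.42 log units; beyond the scatter). The estimate for compound 3 in this assay is 11000 nM, with an expected range from 4500 nM to 27000 nM.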

Compound 3, half-maximal inhibitory concentration: 3050 nM
Compound 3: middle estimate off by 3.6-fold (0.56 log units), on the high side; measured number below the stated range.
By their numbers in this assay, from the lowest: compounds 3 and 1 (each within the scatter of the next); then compound 2.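

In this assay, the step of a 1.4-fold lower number from compound 1 to compound 3 (0.13 log units; within the scatter) shows that the 3,4,5-trimethoxyphenyl on a double-bonded chain carbon bound to a double-bonded chain carbon can give way to the smaller 4-methoxyphenyl without a change beyond the scatter, so the earlier reading of fewer methoxy groups as a higher number does not hold across the three compounds. The step of a 3.1-fold lower number from compound 2 to compound 3 (0.49 log units; beyond the scatter), with hydrogen in place of methoxy on an aromatic carbon, ties the higher number of compound 2 to the 2,4-dimethoxyphenyl arrangement rather than to the count of methoxy groups alone, with compound 3 going against any simple trend in that count. No measurement bearing on the reason for either step is available.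

The compounds shown leave open whether the number at this chain carbon stays in the same range when the methoxy of the 4-methoxyphenyl is replaced by a dimethylamino group, a chlorine atom or a carboxylic acid. They also leave open how an unsubstituted phenyl compares with the 4-methoxyphenyl in compound 3.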